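Swapping the Aryl Ring of the Chain: Compound 3 Estimated

A few compounds are considered here, and "the series" means these few. Any claim that something is new, unique, unknown or untested is made for them only; others in the source may bear on it.

Compound 1, `COc1cccc(/C=C/C(=O)c2sc(Nc3ccc(Cl)cc3)nc2C)c1`: > 25000 nM
Compound 2, `COc1cccc(/C=C/C(=O)c2sc(Nc3ccccc3)nc2C)c1`: 14300 nM

In a functional assay on BGC-823 cells (Homo sapiens) for cytotoxicity, read by MTT assay (a lower number here means a stronger inhibitor, a higher number a weaker inhibitor), compound 1 gives only a limit, > 25000 nM, so no number is known for it; this is the limit of > 25000 nM in this assay, at which 1 of the 2 values shown sits. Within the data shown here, compound 2 is the only compound with an actual number in this assay, 14300 nM. Among the measured compounds shown here, the one measured step, an at least 1.7-fold lower number from compound 1 to compound 2 (0.24 log units; that floor lies within the scatter), puts hydrogen in place of chloro on an aromatic carbon, and it stays within the scatter.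

Compound 3, `Cc1nc(Nc2ccccc2)sc1C(=O)/C=C/c1ccc(Cl)cc1`, differs from compound 2 by 4-chlorophenyl in place of 3-methoxyphenyl on a double-bonded chain carbon bound to a double-bonded chain carbon. For the measured compounds named here, the only measured step concerns a different part of the molecule and itself lies within the scatter, so it gives no guide to this exchange. No step beyond the scatter is therefore expected in this assay. Compound 3 is estimated at 14000 nM, within 4000 nM to 40000 nM. This corresponds to an expected step of a 1.0-fold lower number from compound 2 to compound 3 (0.01 log units; within the scatter).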

Compound 3, half-maximal inhibitory concentration: > 25000 nM
Compound 3 gave a limit, no number (the forecaster's own chance of this, stated with the estimate: 35%); at least 1.7-fold (0.25 log units) between middle value and limit.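

The exchange of 3-methoxyphenyl for 4-chlorophenyl on a double-bonded chain carbon bound to a double-bonded chain carbon gives the first reading at this place, an at least 1.7-fold higher number from compound 2 to compound 3 (0.24 log units; that floor lies within the scatter), so a real loss is not shown, although the true step could be larger. Compound 3 gives a limit and not a number, so only a floor can be read for the step: the limit of > 25000 nM in this assay, at which 2 of the 3 values shown sit. Each of the two single changes from compound 2 that bring in a 4-chlorophenyl, one in compound 1 and one in compound 3, ends at a limit, whichever part of the molecule carries it.

On these data alone, this exchange removes the methoxy group and adds the chloro group in one move, so their separate contributions remain unknown. A plain phenyl or a phenyl bearing an amine at this place would help to separate them.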